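Alkyne-terminus variation and rat half-life: compound 3

A few compounds are considered here, and "the series" means these few. Any claim that something is new, unique, unknown or untested is made for them only; others in the source may bear on it.

Measured so far:
- compound 1 `NC(=O)c1cc(Cl)c2c(Cl)c(C#CC3CCOCC3)n([C@H]3CCCNC3)c2n1`: 7.41 h
- compound 2 `COCCC#Cc1c(Cl)c2c(Cl)cc(C(N)=O)nc2n1[C@H]1CCCNC1`: 2.75 h

Going by the values given here, compound 2 stands lowest of the two numbers in an ADME assay on the whole organism (Rattus norvegicus) for metabolic stability, at a dose of 3 mg/kg by the intravenous route; on this read-out higher numbers stand for a longer-lived compound and lower numbers for a shorter-lived compound; its nearest neighbour is compound 1 with a higher number, the one recorded step being a 2.7-fold lower number from compound 1 to compound 2 (0.43 log units; beyond the scatter), which is 2-methoxyethyl in place of oxan-4-yl on a triple-bonded carbon. Compound 3 `NC(=O)c1cc(Cl)c2c(Cl)c(C#CC3CCCO3)n([C@H]3CCCNC3)c2n1` carries oxolan-2-yl in place of 2-methoxyethyl on a triple-bonded carbon. Among the compounds with values here, a ring thus returns at the alkyne terminus, though not the oxan-4-yl of compound 1, so the only step bearing on it is a 2.7-fold lower number from compound 1 to compound 2 (0.43 log units; beyond the scatter), modest and beyond the scatter, read in reverse. A rise in this assay of roughly that order is expected, but with the ring differing from that of compound 1 the full recovery is uncertain. For compound 3 the expected step is a 1.8-fold higher number from compound 2 to compound 3 (0.26 log units; within the scatter). Compound 3 is estimated at 5 h, ranging from 2.5 h to 10 h.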

Compound 3, half-life: 2.32 h
Beside the measured number, compound 3's estimate is 2.2-fold (0.33 log units) above it; measured number outside the range, below it.
By their numbers in this assay, from the lowest: compounds 3 and 2 (each within the scatter of the next); then compound 1.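

Carrying a ring on the triple-bonded carbon does not by itself go with a longer half-life: in this assay oxolan-2-yl and 2-methoxyethyl are indistinguishable, with a 1.2-fold lower number from compound 2 to compound 3 (0.07 log units; within the scatter) as the step between them. Compound 1 alone stands apart, with a 3.2-fold lower number from compound 1 to compound 3 (0.50 log units; beyond the scatter) showing that the ring's identity matters here, so the link between a ring and the higher number seen with oxan-4-yl fails for compound 3. Nothing available accounts for either step.

Oxolan-2-yl and oxan-4-yl differ in both ring size and point of attachment, and the compounds shown do not separate the two. Oxan-2-yl and oxolan-3-yl would address that question, while cyclohexyl would test whether the ring oxygen is needed at all.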